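This account rests on a few compounds, and the source may have more. Where it says the series, first, only, none or still open, it means among the compounds named here.

In a functional assay on A549 cells (Homo sapiens) for cytotoxicity, read by MTT assay, with a stated time of 72 h (a higher number here means a weaker inhibitor, a lower number a stronger inhibitor), compound 2 `O=C(Nc1nc2ccccc2s1)c1cn(-c2ccccc2)nc1-c1ccc(F)cc1` gives 9010 nM, while compound 1 `O=C(Nc1nc2ccc(F)cc2s1)c1cn(-c2ccccc2)nc1-c1ccccc1` gives 10200 nM; these two numbers lie within the scatter of each other, so the two compounds cannot be told apart on this read-out. Compound 3 `O=C(Nc1nc2ccc(F)cc2s1)c1cn(-c2ccccc2)nc1-c1ccc(F)cc1` has not yet been measured. It differs from compound 2 by fluoro in place of hydrogen on an aromatic carbon. Compound 1 already carries this same fluoro and gives 10200 nM, within the scatter of the number of compound 2, so no step beyond the scatter is expected here. Compound 3 is therefore estimated at 9500 nM, with a range from 4000 nM to 25000 nM. The step of a 1.1-fold higher number from compound 2 to compound 3 (0.02 log units; within the scatter) is expected to be small.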

Compound 3, half-maximal inhibitory concentration: 6650 nM
For compound 3 the middle estimate is 1.4-fold (0.15 log units) above the measured one; the range from low to high includes it.
By their numbers in this assay, from the lowest: compounds 3, 2 and 1 (each within the scatter of the next).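

Going from 1,3-benzothiazol-2-yl to 6-fluoro-1,3-benzothiazol-2-yl in this assay gives a 1.4-fold lower number from compound 2 to compound 3 (0.13 log units; within the scatter) and the other single fluoro swap gives a 1.5-fold lower number from compound 1 to compound 3 (0.19 log units; within the scatter) in the same read-out. Compound 3 carries both fluoro groups, yet neither swap moves the number beyond the scatter, so having both fluoro groups on the shared core does not separate compound 3 from compound 1 or compound 2. Nothing measured here explains these numbers. Still open, as far as these compounds go, is whether a larger group on this aromatic carbon, such as an amine, methoxy or a carboxylic acid, would give a step beyond the scatter.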